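The source may hold more compounds than are shown below. What is called first, only, known or untested is meant among the compounds shown, and "the series" means these compounds.

Going by the values given here, compound 2 `Oc1cccc(-c2cc(-c3ccoc3)cc(-c3cccc(O)c3)n2)c1` gives 1020 nM in a functional assay on HCT-15 cells (Homo sapiens) for cytotoxicity, read by CCK-8 assay (on this read-out lower numbers stand for stronger inhibition and higher numbers for weaker inhibition), the only plain number in this small set. Compound 1 `Oc1ccc(-c2cc(-c3ccoc3)cc(-c3ccccc3O)n2)cc1` reaches only the limit of > 50000 nM in this assay. The other shown value is therefore (the limit of > 50000 nM in this assay, at which 1 of the 2 values shown sits). Compound 3 `Oc1ccc(-c2cc(-c3ccoc3)cc(-c3cccc(O)c3)n2)cc1` has the same atoms as compound 2, joined differently: 4-hydroxyphenyl in place of 3-hydroxyphenyl on an aromatic carbon. Among the compounds with values here, no step between measured compounds is available, so the size of this change is open; a moderate loss beyond the scatter seems the likelier outcome. Compound 3 is expected to give an estimated 4000 nM (range 1000 nM to 30000 nM), a step of a 3.9-fold higher number from compound 2 to compound 3 (0.59 log units; beyond the scatter).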

Compound 3, half-maximal inhibitory concentration: 930 nM
Compound 3: the middle estimate sits 4.3-fold (0.63 log units) above what was measured; measured number below the stated range.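

Swapping 3-hydroxyphenyl for 4-hydroxyphenyl on the aromatic carbon next to the ring nitrogen makes no real difference in this assay, with a 1.1-fold lower number from compound 2 to compound 3 (0.04 log units; within the scatter). By contrast, with 4-hydroxyphenyl kept, placing 3-hydroxyphenyl instead of 2-hydroxyphenyl on the other aromatic carbon gives an at least 53-fold lower number from compound 1 to compound 3 (1.73 log units; beyond the scatter). The value for compound 1 is a limit of the assay, not a number: the limit of > 50000 nM in this assay, at which 1 of the 3 values shown sits.

On these data alone, whether a methoxy group or an amine could replace the hydroxyl on these phenyl rings remains open. So does whether the furan-3-yl group could be exchanged for another ring.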